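The compounds below may be only part of what the source reports. "The series", "measured", "known", "first", "only" and "open" are said of these compounds alone.

Compound 1 `CCCOc1ccc(C(=O)Nc2cccc(Br)n2)cc1` gives 80700 nM in an in vitro assay on HEK-tsA201 cells for antagonist activity at Neuronal acetylcholine receptor; alpha4/beta2 (Homo sapiens), read by fluorescence and calcium flux; a lower number here means a stronger inhibitor, a higher number a weaker inhibitor. Compound 2 `CCCOc1ccc(C(=O)Nc2cccc(CC)n2)cc1` gives 37600 nM in this assay. Compound 3 `CCCOc1ccc(C(=O)Nc2cccc(Nc3ccc(F)cc3)n2)cc1` gives > 100000 nM in this assay, which is a limit of the assay and not a number.

Among these three, compound 3 stands at the limit described in the limit of > 100000 nM in this assay, at which 1 of the 3 values shown sits, the weakest position the assay can report. Within the data shown here, the step of a 2.1-fold lower number from compound 1 to compound 2 (0.33 log units; beyond the scatter) is the only one that moves a value clearly downward. Both steps into compound 3 run the other way: an at least 1.2-fold higher number from compound 1 to compound 3 (0.09 log units; that floor lies within the scatter) and an at least 2.6-fold higher number from compound 2 to compound 3 (0.42 log units; beyond the scatter). An arylamino group on that aromatic carbon thus carries the number out of the measurable window.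

Compound 4 `CCCOc1ccc(C(=O)Nc2cccc(NCc3ccccc3)n2)cc1` has not yet been measured in this assay. It differs from compound 3 by benzyl in place of 4-fluorophenyl on a nitrogen on an aromatic ring. Among the measured compounds shown here, only the steps into compound 3 bear on this change, and they both end at the limit, so no step beyond the scatter is expected from compound 3 to compound 4. Compound 4 is therefore estimated at 100000 nM, within 40000 nM to 300000 nM. The expected step is a number no higher from compound 3 to compound 4 (the limit leaves the size open).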

Compound 4, half-maximal inhibitory concentration: > 100000 nM
Compound 4: a limit, no number (the forecaster's own chance of this, stated with the estimate: 60%); the middle value sits exactly at the limit.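

In this assay, replacing ethyl with benzylamino on that aromatic carbon gives an at least 2.6-fold higher number from compound 2 to compound 4 (0.42 log units; beyond the scatter), a clear move, whereas replacing bromo with benzylamino gives only an at least 1.2-fold higher number from compound 1 to compound 4 (0.09 log units; that floor lies within the scatter). The step between compound 3 and compound 4 cannot be read, as both values are limits of the assay and not numbers. The new result shows that the limit is not peculiar to 4-fluorophenyl on that nitrogen, as it holds for benzyl as well: the limit of > 100000 nM in this assay, at which 2 of the 4 values shown sit.

From the compounds shown here alone, it remains open whether a plain amine or a methylamino group on that aromatic carbon would give a number inside the measurable window. Going by these compounds, it is also open whether a propyl or butyl chain there would carry the number lower than the ethyl group of compound 2 does.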